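Carbinol in place of sulfoximine on a shared core

The source may report more compounds than this note shows. Statements on the series, on what has been measured and on what is new or still open speak of the compounds shown alone.

Compound 1 `CC#C[C@H]1CN(S(=O)(=O)c2ccc(N)nc2)CCN1c1ccc(S(=O)(=NC)C(F)(F)F)cc1` gives 2060 nM in an assay on cells (Hepatocyte) for inhibition of glucokinase regulatory protein (Mus musculus), with stated times of 20 min and 40 min (on this read-out higher numbers stand for an effect only at larger amounts of compound and lower numbers for an effect already at smaller amounts), the highest of the two numbers recorded here. Compound 2 `CC#C[C@H]1CN(S(=O)(=O)c2ccc(N)nc2)CCN1c1ccc(C(O)(COC)C(F)(F)F)cc1` gives 202 nM in this assay. Compound 3 `CC#C[C@H]1CN(S(=O)(=O)c2ccc(N)nc2)CCN1c1ccc(C(C)=O)cc1` is held at a limit of the assay, > 12500 nM in this assay, which is the limit of > 12500 nM in this assay, at which 1 of the 3 values shown sits. The step of a 10-fold lower number from compound 1 to compound 2 (1.01 log units; beyond the scatter) is large, whereas an at least 6.0-fold higher number from compound 1 to compound 3 (0.78 log units; beyond the scatter) runs the other way. Compound 4 `CC#C[C@H]1CN(S(=O)(=O)c2ccc(N)nc2)CCN1c1ccc(C(O)(CC#N)C(F)(F)F)cc1` differs from compound 1 by a group of 9 heavy atoms (4 carbon, 1 nitrogen, 1 oxygen, 3 fluorine; no ring) in place of a group of 8 heavy atoms (2 carbon, 1 nitrogen, 1 oxygen, 3 fluorine, 1 sulfur; no ring), on an aromatic carbon. Among the compounds with values here, the change closely resembles the one leading to compound 2, and that step is the one that bears on it. A sizeable fall is therefore expected for compound 4, with an estimated value of 300 nM, between 100 nM and 900 nM. The expected step is a 6.9-fold lower number from compound 1 to compound 4 (0.84 log units; beyond the scatter).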

Compound 4, half-maximal effective concentration: 219 nM
The estimate for compound 4 lay 1.4-fold (0.14 log units) above the measured number; the range from low to high includes it.
By their numbers in this assay, from the lowest: compounds 2 and 4 (each within the scatter of the next); then compound 1. At a limit, above all of these: compound 3.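

A second side chain on the carbinol carbon now repeats the gain over the sulfoximine, a 9.4-fold lower number from compound 1 to compound 4 (0.97 log units; beyond the scatter), so that gain does not rest on the methoxy group of compound 2 alone. Cyano in place of methoxy on the saturated chain carbon leaves the two carbinols unseparated, a 1.1-fold higher number from compound 2 to compound 4 (0.04 log units; within the scatter), and so within the scatter. The large step of an at least 57-fold lower number from compound 3 to compound 4 (1.75 log units; beyond the scatter) starts from a limit, not a number: the limit of > 12500 nM in this assay, at which 1 of the 4 values shown sits.

From the compounds shown here alone, what an amine, a carboxylic acid or a longer chain in place of cyano would give stays open. So does the part played by the hydroxyl, which both carbinols shown carry.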